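The source may hold more compounds than are shown below. What is called first, only, known or untested is meant among the compounds shown, and "the series" means these compounds.

Three cyclic peptides sharing one core have been tested in a functional assay on P388 cells (Mus musculus) for cytotoxicity; a lower number here means a stronger inhibitor, a higher number a weaker inhibitor. Compound 1 `COc1ccc(C[C@H]2C(=O)N[C@@H](C)C(=O)N(C)[C@H]3Cc4ccc(cc4)Oc4cc(ccc4OC)C[C@@H](C(=O)N[C@H](C)C(=O)N[C@@H](CCC(=O)O)C(=O)N2C)N(C)C3=O)cc1` gives 219 nM in this assay. Within the data shown here, compound 2 `COc1ccc(C[C@H]2C(=O)N[C@@H](C)C(=O)N(C)[C@H]3Cc4ccc(cc4)Oc4cc(ccc4OC)C[C@@H](C(=O)N[C@H](C)C(=O)N[C@@H](CCO)C(=O)N2C)N(C)C3=O)cc1` gives 60.3 nM, and the only measured single-point step, a 3.6-fold lower number from compound 1 to compound 2 (0.56 log units; beyond the scatter), came from swapping one small group for another on a side chain. Compound 3 `CCN1C(=O)[C@@H](C)NC(=O)[C@@H]2Cc3ccc(OC)c(c3)Oc3ccc(cc3)C[C@@H](C(=O)N2C)N(C)C(=O)[C@H](C)NC(=O)[C@H](Cc2ccc(OC)cc2)N(C)C(=O)[C@@H]1C` gives 43.7 nM, the lowest of the three numbers; its gap to compound 2 lies within the scatter, so the two cannot be ranked, while its gap to compound 1 lies beyond the scatter.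

Compound 4 `COc1ccc(C[C@H]2C(=O)N[C@@H](C)C(=O)N(C)[C@H]3Cc4ccc(cc4)Oc4cc(ccc4OC)C[C@@H](C(=O)N[C@H](C)C(=O)N(C/C=C(\C)CCC=C(C)C)[C@@H](C)C(=O)N2C)N(C)C3=O)cc1` has not yet been measured. It differs from compound 3 in a single place: 2,6-dimethylhepta-1,5-dien-1-yl in place of methyl on a saturated chain carbon bound to an amide-type nitrogen in a ring. Among the measured compounds shown here, no measured step touches this position or this kind of change. For the measured compounds named here, the one step that exists, a 3.6-fold lower number from compound 1 to compound 2 (0.56 log units; beyond the scatter), replaced carboxy with hydroxy elsewhere on the ring, whereas the change to compound 4 brings in a nine-carbon chain with two double bonds and no hydrogen-bond donors or acceptors. With nothing comparable in the data, no clear direction can be read off, and a step of modest size in either sense, or none beyond the scatter, is expected. Compound 4 is therefore estimated at 60 nM, within a range from 15 nM to 250 nM. That estimate means an expected step of a 1.4-fold higher number from compound 3 to compound 4 (0.14 log units; within the scatter).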

Compound 4, half-maximal inhibitory concentration: 49 nM
Compound 4: the middle estimate sits 1.2-fold (0.09 log units) above what was measured; measured number inside the range.
By their numbers in this assay, from the lowest: compounds 3, 4 and 2 (each within the scatter of the next); then compound 1.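

In this assay, putting 2,6-dimethylhepta-1,5-dien-1-yl in place of methyl on a saturated chain carbon bound to an amide-type nitrogen in a ring gives a 1.1-fold higher number from compound 3 to compound 4 (0.05 log units; within the scatter). The earlier step, a 3.6-fold lower number from compound 1 to compound 2 (0.56 log units; beyond the scatter), came from a different change, hydroxy in place of carboxy, and said nothing about this position; here, 9 heavy atoms can stand where 1 stood with no shift beyond the usual scatter, so at least this long chain with its 2 double bonds is accepted in this cytotoxicity read-out. No measurement in hand explains why the number holds steady.

This single pair cannot show whether the position accepts anything else, such as an amine, a carboxylic acid or a fully saturated chain of similar length, so its tolerance may or may not extend beyond this one hydrocarbon group. It also leaves open whether the same long chain would behave the same way when combined with the hydroxy side chain of compound 2 or the carboxy side chain of compound 1.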